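The compounds below may be only part of what the source reports. "The series", "measured", "known", "first", "only" and "open" are said of these compounds alone.

Measured so far:
Compound 1, `COc1ccc(-c2cnc(NC(=O)c3ccc([N+](=O)[O-])cc3)n2C)cc1`: > 100000 nM
Compound 2, `COc1ccc(-c2cnc(NC(=O)c3ccccc3)n2C)cc1`: > 100000 nM

Compound 2, `COc1ccc(-c2cnc(NC(=O)c3ccccc3)n2C)cc1`, is the starting point. In a toxicity assay on THP-1 cells (Homo sapiens) for inhibition (on this read-out higher numbers stand for lower toxicity in this test and lower numbers for higher toxicity in this test), compound 2 gives > 100000 nM, which is a limit of the assay and not a number. Compound 1, `COc1ccc(-c2cnc(NC(=O)c3ccc([N+](=O)[O-])cc3)n2C)cc1`, gives > 100000 nM in this assay, again a limit. Going by the values given here, the only measured step, a step that the two limits leave unreadable from compound 1 to compound 2, therefore has no readable size, since the limit of > 100000 nM in this assay, at which 2 of the 2 values shown sit, holds both values. Compound 3, `COc1ccc(-c2cnc(NC(=O)c3ccncc3)n2C)cc1`, differs from compound 2 by pyridin-4-yl in place of phenyl on a carbonyl carbon. Among the compounds with values here, no measured step involves pyridin-4-yl in place of phenyl on a carbonyl carbon, so nothing in the data fixes the size or direction of this change. With both measured compounds at the limit, compound 3 is expected to give a step that the limit leaves unreadable from compound 2 to compound 3 in this assay, that is none beyond the scatter. The value of compound 3 is accordingly estimated at 150000 nM, in a range from 60000 nM to 400000 nM, most likely reported again as a limit.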

Compound 3, half-maximal cytotoxic concentration: > 100000 nM
Compound 3: no number, only a limit (the forecaster's own chance of this, stated with the estimate: 85%); the middle value does not contradict the limit.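

In this assay compound 3 gives > 100000 nM, again a limit of the assay and not a number, so the step between compound 2 and compound 3 cannot be read. The compounds shown leave open whether any change to the shared core would give a readable value.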